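Ethyl to cyclopropylmethyl on the amine nitrogen

The source may hold more compounds than are shown below. What is called first, only, known or untested is meant among the compounds shown, and "the series" means these compounds.

In a physicochemical assay for solubility, at pH 1.1 (on this read-out higher numbers stand for higher solubility and lower numbers for lower solubility), compound 2 (`CCN(Cc1ccc(OCCN2C(=O)CCC2=O)c(C)c1)C(CC(=O)O)c1ccc(Cl)cc1`) gives 3000000 nM, level with compound 1 (`CCCN(Cc1ccc(OCCN2C(=O)CCC2=O)c(C)c1)C(CC(=O)O)c1ccc(Cl)cc1`) at 3000000 nM. Compound 3 (`Cc1cc(CN(CC2CC2)C(CC(=O)O)c2ccc(Cl)cc2)ccc1OCCN1C(=O)CCC1=O`) keeps the shared core and differs by cyclopropyl in place of methyl on a saturated chain carbon bound to an amine nitrogen, which is cyclopropyl in place of methyl on a saturated chain carbon bound to an amine nitrogen. The same difference, cut one bond further out, reads ethyl to cyclopropylmethyl. For the measured compounds named here, one measured step bears on this chain: no change at the digits printed from compound 1 to compound 2 (within the scatter), hydrogen in place of methyl on a saturated chain carbon, two bonds along the chain from an amine nitrogen. It involves no ring, so it is only an indirect guide. On that single step, no shift beyond the scatter is expected in this assay. The expected step is no change at the digits printed from compound 2 to compound 3 (within the scatter). For compound 3 the estimated value is 3000000 nM, within an expected range of 1500000 nM to 4000000 nM.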

Compound 3, solubility: 3000000 nM
For compound 3 middle estimate and measured number coincide at the digits printed; the range from low to high includes it.
By their numbers in this assay, from the lowest: compounds 1, 2 and 3 (each within the scatter of the next).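

In this assay the earlier pair spoke only to a shorter or longer open chain, whereas this position now also carries a ring: cyclopropyl in place of methyl on a saturated chain carbon bound to an amine nitrogen gives no change at the digits printed from compound 2 to compound 3 (within the scatter) in this read-out. Set against the propyl compound, cyclopropyl in place of ethyl at that place gives no change at the digits printed from compound 1 to compound 3 (within the scatter) as well, so one three-membered non-aromatic ring of carbon only is tolerated here on the printed values of these three compounds. No supporting measurement is available that would explain this flat result.

From the compounds shown here alone, whether an amine or a carboxylic acid carried on a longer chain at this nitrogen would read the same stays open. Also open, going by these compounds, is how a six-membered ring such as phenyl would read at this place.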